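Hydrazone triazolyl-pyridyl ethers: a triazole swap

This account rests on a few compounds, and the source may have more. Where it says the series, first, only, none or still open, it means among the compounds named here.

Two compounds of the series carry the same core and differ only on the carbon with a double bond to nitrogen. Compound 1 `CN(C)CCn1cnnc1-c1cc(Oc2ccc(NC(=O)N/N=C/c3c(Cl)cccc3Cl)cc2F)ccn1` in a functional assay on A549 cells (Homo sapiens) for cytotoxicity, read by MTT assay, with a stated time of 72 h (on this read-out lower numbers stand for stronger inhibition and higher numbers for weaker inhibition), gives 1410 nM. Compound 2 `CN(C)CCn1cnnc1-c1cc(Oc2ccc(NC(=O)N/N=C/c3ccccc3)cc2F)ccn1` in this assay gives 1860 nM. For the measured compounds named here, the step of a 1.3-fold higher number from compound 1 to compound 2 (0.12 log units; within the scatter) is the only measured step. On the numbers shown, compound 2 stands highest of the two, with compound 1 its nearest neighbour and within the scatter of it, so no order can be drawn between them.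

Compound 3 `Cn1ncnc1-c1cc(Oc2ccc(NC(=O)N/N=C/c3ccccc3)cc2F)ccn1` is not yet measured. It differs from compound 2 by 1-methyl-1H-1,2,4-triazol-5-yl in place of 4-(2-(dimethylamino)ethyl)-4H-1,2,4-triazol-3-yl on an aromatic carbon. Going by the values given here, no measured step touches this part of the molecule: the one step in hand concerns the hydrazone aryl group and says nothing about the triazole or its substituent. The expectation therefore rests on compound 2 alone and carries a wide range in either direction. A step of a 1.5-fold higher number from compound 2 to compound 3 (0.18 log units; within the scatter) is estimated, which is a guess at a modest change rather than a reading of the data. Compound 3 is expected to give about 2800 nM in this assay, within 900 nM to 9000 nM.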

Compound 3, half-maximal inhibitory concentration: > 100000 nM
Compound 3 gave a limit, no number (the forecaster's own chance of this, stated with the estimate: 10%); middle value at least 35-fold (1.55 log units) away from the limit.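

This position on the shared core, an aromatic carbon next to the ring nitrogen, responds far more strongly in this assay than the hydrazone aryl group: the triazole swap gives an at least 53-fold higher number from compound 2 to compound 3 (1.73 log units; beyond the scatter), whereas the aryl change gives a 1.3-fold higher number from compound 1 to compound 2 (0.12 log units; within the scatter). The swap replaces 4-(2-(dimethylamino)ethyl)-4H-1,2,4-triazol-3-yl with 1-methyl-1H-1,2,4-triazol-5-yl, changing the point of attachment on the triazole and the substituent together, so this single step cannot assign the effect to either one. Compound 3 gives a limit of the assay and not a number: the limit of > 100000 nM in this assay, at which 1 of the 3 values shown sits.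

The compounds shown leave open whether the dimethylamino group, the ethyl chain or the triazole attachment accounts for the step; a 4-methyl-4H-1,2,4-triazol-3-yl group, or a 1-(2-(dimethylamino)ethyl)-1H-1,2,4-triazol-5-yl group, would separate these parts. Also open, from the compounds shown here alone, is whether the 1-methyl-1H-1,2,4-triazol-5-yl group has the same effect when the hydrazone carries 2,6-dichlorophenyl, as in compound 1, and whether another amine, such as a morpholine on the same chain, could stand in for the dimethylamino group.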